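Acrylamide thiazole series: the step from compound 1 to compound 4

The compounds below may be only part of what the source reports. "The series", "measured", "known", "first", "only" and "open" are said of these compounds alone.

compound 1 `C=C(Br)C(=O)Nc1cccc(-c2cn3nc(-c4ccc(OC)c(OC)c4)sc3n2)c1`: 380 nM
compound 2 `C=C(Br)C(=O)Nc1cccc(-c2cn3c(-c4ccccc4)csc3n2)c1`: 2800 nM
compound 3 `COc1ccc(-c2csc3nc(-c4cccc(N)c4)cn23)cc1`: 6100 nM

All three were read in a functional assay on CCRF-CEM cells (Homo sapiens) for inhibition, read by cell counting, with a stated time of 3 days; on this read-out higher numbers stand for weaker inhibition and lower numbers for stronger inhibition. Compound 1 gives the lowest number of the three, and compound 2 and compound 3 both lie beyond the scatter from it, so compound 1 is the most potent of this set. For the measured compounds named here, no two measured compounds differ in a single place, so no single-change step is known.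

Compound 4 `C=C(Br)C(=O)Nc1cccc(-c2cn3nc(Cc4ccc(Cl)cc4)sc3n2)c1` has not been measured. It differs from compound 1 as follows: 4-chlorobenzyl in place of 3,4-dimethoxyphenyl on an aromatic carbon. The measured set holds no exchange of this kind, so the direction is uncertain. A move to a higher number, beyond the scatter, is expected; the step is expected to be a 2.6-fold higher number from compound 1 to compound 4 (0.42 log units; beyond the scatter). Compound 4 is therefore estimated at 1000 nM, within 250 nM to 4000 nM.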

Compound 4, half-maximal inhibitory concentration: 3300 nM
Estimate against measurement, compound 4: 3.3-fold (0.52 log units) below; the measured number falls inside the stated range.
By their numbers in this assay, from the lowest: compound 1; then compounds 2, 4 and 3 (each within the scatter of the next, the first and the last beyond it).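

In this assay, for the compounds shown here, the only single-place exchange in the set gives an 8.7-fold higher number from compound 1 to compound 4 (0.94 log units; beyond the scatter) and shows that potency at this aromatic carbon, next to the ring nitrogen and the ring sulfur, depends on the group it carries. With the core of compound 1 held constant, 4-chlorobenzyl does not match 3,4-dimethoxyphenyl. Nothing available explains this loss.

This exchange changes the link to the core and the ring substituents together, leaving their contributions unseparated. As far as these compounds go, a 4-chlorophenyl or unsubstituted benzyl group would separate them, while an amine at this position remains untested here.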